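Ring Closure of the Aryl Ether Side Group

A few compounds are considered here, and "the series" means these few. Any claim that something is new, unique, unknown or untested is made for them only; others in the source may bear on it.

Compound 1 `CCc1ccccc1OC1CCN(c2ccc(-n3ccnc3)nn2)CC1` is the starting point. Within the data shown here, in an assay on microsomes from liver for inhibition of acyl-CoA desaturase 1 (Rattus norvegicus) (a lower number here means a stronger inhibitor, a higher number a weaker inhibitor), compound 1 gives 4 nM, level with its single measured neighbour. Among the measured compounds shown here, that neighbour, compound 2 `FC(F)(F)c1ccccc1OC1CCN(c2ccc(-n3ccnc3)nn2)CC1`, gives 4 nM in this assay, and the one measured step, no change at the digits printed from compound 1 to compound 2 (within the scatter), stays within the scatter. Compound 3 `c1cc2c(c(OC3CCN(c4ccc(-n5ccnc5)nn4)CC3)c1)CCC2` is not yet measured. It differs from compound 1 in one place: 2,3-dihydro-1H-inden-4-yl in place of 2-ethylphenyl on an oxygen on a saturated carbon. For the measured compounds named here, no measured step touches this change directly; the only comparison available shows that replacing the ethyl group with trifluoromethyl left the read-out in this assay where it was. On that basis no step beyond the scatter is expected in either direction. Compound 3 is therefore estimated to give 4 nM in this assay, with a likely range from 1.5 nM to 12 nM. The expected step of no change at the digits printed from compound 1 to compound 3 (within the scatter) is thus one within the scatter.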

Compound 3, half-maximal inhibitory concentration: 10 nM
Compound 3: middle estimate off by 2.5-fold (0.40 log units), on the low side; low and high end bracket the measured number.
By their numbers in this assay, from the lowest: compounds 1 and 2 (each within the scatter of the next); then compound 3.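

Closing the side group into a ring, with 2,3-dihydro-1H-inden-4-yl in place of 2-ethylphenyl on an oxygen on a saturated carbon, gives the first step beyond the scatter in this series: in this assay it reads a 2.5-fold higher number from compound 1 to compound 3 (0.40 log units; beyond the scatter) and is a modest weakening. The position is therefore not indifferent to every change, since the swap of ethyl for trifluoromethyl gave no change at the digits printed from compound 1 to compound 2 (within the scatter) while the ring closure moved the number. Nothing in the data at hand accounts for this difference.

From the compounds shown here alone, it remains open whether the step belongs to the five-membered non-aromatic ring itself or to the extra carbon it brings, and whether a six-membered saturated ring would read differently. Going by these compounds, how a methoxy group or an amine in place of the ethyl group would read in this assay is also open.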